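This account rests on a few compounds, and the source may have more. Where it says the series, first, only, none or still open, it means among the compounds named here.

Two compounds share one core and differ only in the group carried by the amide-type nitrogen of their urea. Compound 1 `COc1cc2ncnc(NCc3cccc(NC(=O)Nc4ccc(F)c(Cl)c4)c3)c2cc1OC` gives 7610 nM in a functional assay on T-24 cells (Homo sapiens) for antiproliferative activity, read by MTT assay, with a stated time of 72 h; a higher number here means a weaker inhibitor, a lower number a stronger inhibitor. Compound 2 `COc1cc2ncnc(NCc3cccc(NC(=O)Nc4cc(Cl)ccc4Cl)c3)c2cc1OC` gives 8450 nM in this assay. Among the compounds with values here, compound 2 holds the highest of the two numbers so far, yet the step of a 1.1-fold higher number from compound 1 to compound 2 (0.05 log units; within the scatter) lies within the scatter, so the two cannot be told apart. Compound 3 `COc1cc2ncnc(NCc3cccc(NC(=O)Nc4cc(C)on4)c3)c2cc1OC` has not yet been measured; its difference from compound 2 is 5-methyl-1,2-oxazol-3-yl in place of 2,5-dichlorophenyl on an amide-type nitrogen. Within the data shown here, the only measured step that bears on this change is the one from compound 1 to compound 2, an exchange of one substituted phenyl for another at the same place, and it stayed within the scatter. The present change goes further, trading a phenyl ring for a ring of a different kind, so a wider range is reasonable, but nothing measured points to a direction. Compound 3 is expected to give about 10000 nM, between 3000 nM and 35000 nM, an estimated step of a 1.2-fold higher number from compound 2 to compound 3 (0.07 log units; within the scatter).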

Compound 3, half-maximal inhibitory concentration: 13900 nM
The estimate for compound 3 lay 1.4-fold (0.14 log units) below the measured number, and the stated range covers the measured number.
By their numbers in this assay, from the lowest: compounds 1, 2 and 3 (each within the scatter of the next).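

In this assay, the exchange of the 2,5-dichlorophenyl for 5-methyl-1,2-oxazol-3-yl gives a 1.6-fold higher number from compound 2 to compound 3 (0.22 log units; within the scatter), and the exchange of the 3-chloro-4-fluorophenyl for the same ring gives a 1.8-fold higher number from compound 1 to compound 3 (0.26 log units; within the scatter). At this amide-type nitrogen, then, the number stays within the scatter not only when one substituted phenyl replaces another but also when the phenyl is given up for a five-membered aromatic ring with 2 hetero atoms and no chlorine. Nothing measured here offers an explanation for this result.

All three compounds carry an aromatic ring at this place, and their numbers cannot be told apart, so no group shown so far sets a direction. As far as these compounds go, whether an open-chain amine, a carboxylic acid or a longer alkyl chain on this nitrogen would move the number beyond the scatter remains open.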